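Changing the halogenated ring on the ketone carbonyl

The compounds below may be only part of what the source reports. "The series", "measured", "known", "first", "only" and "open" are said of these compounds alone.

Compound 1 `COC(=O)c1cc(-c2cccc(NC(=O)c3ccc(/C=C/C(=O)c4ccccc4Br)cc3)c2)on1`, compound 2 `COC(=O)c1cc(-c2cccc(NC(=O)c3ccc(/C=C/C(=O)c4ccc(Br)cc4)cc3)c2)on1` and compound 3 `COC(=O)c1cc(-c2ccc(NC(=O)c3ccc(/C=C/C(=O)c4ccc(Cl)cc4)cc3)cc2)on1` share one core and were tested in an ADME assay on Vero cells (Chlorocebus sabaeus) for cytotoxicity, read by MTT assay, with a stated time of 72 h; a lower number here means that less compound is tolerated, a higher number that more compound is tolerated. For compound 1 the result is only a limit, > 40 ug/mL. For compound 2 the result is also a limit, > 20 ug/mL. For compound 3 the result is again a limit, > 80 ug/mL. Because all three results are limits (the limit of > 20 ug/mL in this assay, at which 1 of the 3 values shown sits, (the limit of > 40 ug/mL in this assay, at which 1 of the 3 values shown sits), (the limit of > 80 ug/mL in this assay, at which 1 of the 3 values shown sits)), compound 2 stands at a limit alongside the other two values, and the step that the two limits leave unreadable from compound 1 to compound 2 has no readable size.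

Compound 4 `COC(=O)c1cc(-c2cccc(NC(=O)c3ccc(/C=C/C(=O)c4ccccc4Cl)cc3)c2)on1` differs from compound 2 by 2-chlorophenyl in place of 4-bromophenyl on a carbonyl carbon. Among the measured compounds shown here, the only measured step at the same place, a step that the two limits leave unreadable from compound 1 to compound 2, gives no size and so no direction. Every measured compound reached a limit in this assay, so compound 4 is expected to behave alike, with the step that the limit leaves unreadable from compound 2 to compound 4 expected to stay within the scatter. The estimate for compound 4 is 50 ug/mL, between 20 ug/mL and 120 ug/mL.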

Compound 4, half-maximal cytotoxic concentration: > 25 ug/mL
Compound 4: no number, only a limit (the forecaster's own chance of this, stated with the estimate: 80%); the middle value lies beyond the limit too.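

In this assay compound 4 gives > 25 ug/mL, which is only a limit. Compound 1 and compound 2 also gave limits, so neither step to compound 4 can be read. The compounds shown leave open whether changing the halogenated ring on the carbonyl alters tolerated concentration at all.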